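The source may report more compounds than this note shows. Statements on the series, on what has been measured and on what is new or still open speak of the compounds shown alone.

Working notes on a small amide series built on the core of compound 2 `COc1cccc2cc(C(=O)NCCO)c(=N)oc12`. In an assay on HeLa cells for displacement of a labelled ligand from adenosine receptor A3 (Homo sapiens), read by scintillation counting, with a stated time of 180 min, tested at 10 uM (a higher number here means more inhibition at the concentration tested (going by the name of the read-out), a lower number less inhibition), compound 2 gives 23%. Compound 1 `COc1cccc2cc(C(=O)NCC(=O)O)c(=O)oc12` gives 15% in this assay, a number within the scatter of compound 2, so the two cannot be told apart on these data. Compound 3 `COc1ccc(-n2cnc(C#N)c2NC(=O)c2cc3cccc(OC)c3oc2=N)cc1` gives 42%, a number beyond the scatter above compound 2; compound 2 therefore sits below compound 3 and level with compound 1. Compound 4 `COc1cccc2cc(C(=O)NC3CCCCC3)c(=N)oc12` has not yet been measured in this assay. It differs from compound 2 in one place: cyclohexyl in place of 2-hydroxyethyl on an amide-type nitrogen. Among the compounds with values here, no measured pair shows this change, so the expected step is a number 5 percentage points higher from compound 2 to compound 4 (within the scatter), small and not clearly beyond the scatter. Compound 4 is expected to give 28%, within a range from 5% to 55%.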

Compound 4, a percentage reported as inhibition, at one concentration (the size of the read-out at that concentration, not a potency): 16%
Compound 4: the middle estimate sits 12 percentage points above what was measured; measured number inside the range.
By their numbers in this assay, from the lowest: compounds 1, 4 and 2 (each within the scatter of the next); then compound 3.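

In this assay the first step read at this position is a number 7 percentage points lower from compound 2 to compound 4 (within the scatter) for cyclohexyl in place of 2-hydroxyethyl on the amide-type nitrogen. A six-membered carbon ring with no hydrogen-bond donor or acceptor therefore cannot be told apart from the hydroxyl-bearing chain here, so this change does not register on these data. Nothing available accounts for this result.

Within the data shown here, only this one pair speaks to the position. As far as these compounds go, whether a 2-aminoethyl chain, a phenyl ring or a longer chain on this nitrogen would move the number beyond the scatter remains open.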